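Removal of the piperidin-1-yl group from compound 1

A few compounds are considered here, and "the series" means these few. Any claim that something is new, unique, unknown or untested is made for them only; others in the source may bear on it.

Compound 1 `COc1cc(OC)c(Cl)c(-c2ccc3c(NC(=O)c4ccc(N5CCCCC5)cc4)n[nH]c3n2)c1Cl`: 558 nM
Compound 2 `COc1cc(OC)c(Cl)c(-c2ccc3c(NC(=O)c4ccc(N5CCN(C)CC5)cc4Cl)n[nH]c3n2)c1Cl`: 27.6 nM
Compound 3 `COc1cc(OC)c(Cl)c(-c2ccc3c(NC(=O)c4ccc(N5CCN(C)CC5)cn4)n[nH]c3n2)c1Cl`: 4.4 nM

In a functional assay on NCI-H1581 cells (Homo sapiens) for antiproliferative activity, read by CCK-8 assay, with a stated time of 72 h (on this read-out higher numbers stand for weaker inhibition and lower numbers for stronger inhibition), compound 1 gives 558 nM, the highest of the three numbers. Compound 2 gives 27.6 nM, a lower number well beyond the scatter, and compound 3 gives 4.4 nM, lower still. Going by the values given here, none of these pairs differs in a single place, so the values can only be set side by side; no step between measured compounds is known.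

Compound 4 `COc1cc(OC)c(Cl)c(-c2ccc3c(NC(=O)c4ccccc4)n[nH]c3n2)c1Cl` differs from compound 1 in one place: hydrogen in place of piperidin-1-yl on an aromatic carbon. Among the compounds with values here, no measured pair covers this change, so the expectation rests on the three values alone. Every measured compound carries a nitrogen-linked ring on the amide phenyl, and the one with the smallest such group, compound 1, already has the highest number; compound 4 carries none. The step from compound 1 to compound 4 is therefore expected to go toward a higher number, probably beyond the scatter, a 3.2-fold higher number from compound 1 to compound 4 (0.51 log units; beyond the scatter). Compound 4 is expected to give about 1800 nM, with a range from 500 nM to 6000 nM.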

Compound 4, half-maximal inhibitory concentration: > 1000 nM
Compound 4: only a limit was reported; the forecaster's own chance of this, stated with the estimate: 10%; the middle value does not contradict the limit.
By their numbers in this assay, from the lowest: compound 3; then compound 2; then compound 1. At a limit, above all of these: compound 4.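

In this assay compound 4 gives > 1000 nM, which is a limit of the assay and not a number. Going by these compounds alone, the series now has its only single-place step, on an aromatic carbon of a six-membered aromatic ring of carbon only, para to a large group: hydrogen in place of piperidin-1-yl gives an at least 1.7-fold higher number from compound 1 to compound 4 (0.25 log units; that floor lies within the scatter), so the 4-(piperidin-1-yl)phenyl to phenyl change brings no lower number, while the true size of the step remains unresolved because the reading for the phenyl compound stops at a limit: the limit of > 1000 nM in this assay, at which 1 of the 4 values shown sits.

Still open, as far as these compounds go, is how a morpholine ring, an open-chain dimethylamino group or a methoxy group on this same aromatic carbon would read, which would show whether the ring of piperidin-1-yl matters or any substituent at this place will do. Compound 2 and compound 3 differ from compound 1 in more than one place, so a 4-methylpiperazin-1-yl group on the plain phenyl of compound 4 would be needed to tie their values to this carbon.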